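Cytotoxicity of an ester variant on a shared quinolinone core

This account rests on a few compounds, and the source may have more. Where it says the series, first, only, none or still open, it means among the compounds named here.

The series was profiled in an ADME assay on HepG2 2.2.15 cells (Homo sapiens) for cytotoxicity; on this read-out higher numbers stand for lower toxicity in this test and lower numbers for higher toxicity in this test. Compound 1 `C=CCn1c(=O)c(CCO)c(-c2ccccc2Cl)c2cc(Cl)ccc21` gives 23000 nM. Compound 2 `O=CCc1c(-c2ccccc2Cl)c2cc(Cl)ccc2[nH]c1=O` gives 120000 nM. Compound 3 `CC(=O)NCC(=O)OCCc1c(-c2ccccc2Cl)c2cc(Cl)ccc2[nH]c1=O` gives 110000 nM, the second highest of the three numbers; the nearest is compound 2, and the step of a 1.1-fold lower number from compound 2 to compound 3 (0.04 log units; within the scatter) shows that replacing formyl by (((acetamidomethyl)carbonyl)oxy)methyl on a saturated chain carbon bound to an aromatic carbon left the read-out where it was. Compound 1, which differs from compound 3 in more than one place, stands furthest away, with the lower of the two values.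

Compound 4 `O=C(/C=C/c1ccccc1)OCCc1c(-c2ccccc2Cl)c2cc(Cl)ccc2[nH]c1=O` has not been measured. It differs from compound 3 by 2-phenylethenyl in place of acetamidomethyl on a carbonyl carbon. Within the data shown here, no measured pair in this set bears directly on this exchange; the only step available, from a formyl to an ester-bearing chain, stayed within the scatter, so there is no observed trend to extrapolate. Given the limited data, the number for compound 4 is expected to move down from that of compound 3 by about a 1.6-fold lower number from compound 3 to compound 4 (0.20 log units; within the scatter), a change that may still lie within the scatter. Compound 4 is therefore estimated at 70000 nM, with a plausible range from 25000 nM to 160000 nM.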

Compound 4, half-maximal cytotoxic concentration: 230000 nM
The estimate for compound 4 lay 3.3-fold (0.52 log units) below the measured number; the measured number lies above the stated range.
By their numbers in this assay, from the lowest: compound 1; then compounds 3, 2 and 4 (each within the scatter of the next, the first and the last beyond it).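

In this assay the exchange of acetamidomethyl for 2-phenylethenyl on a carbonyl carbon gave a 2.1-fold higher number from compound 3 to compound 4 (0.32 log units; beyond the scatter), a modest move toward lower toxicity in this test. Among these compounds, the earlier step on this side chain, a 1.1-fold lower number from compound 2 to compound 3 (0.04 log units; within the scatter), had stayed within the scatter, so this is the first sign in the set that the group carried on the ester carbonyl can shift the read-out beyond it. The exchange brings in a six-membered aromatic ring of carbon only and removes a hydrogen-bond donor and a hydrogen-bond acceptor, yet no measurement offered here accounts for the rise.

Among the compounds shown here, with only this pair, the ring, the double bond next to it in the name of the group, and the loss of the amide cannot be told apart as the source of the step. A 2-phenylethyl group, a plain phenyl, or an amine or a carboxylic acid on the same carbonyl carbon would be needed to show which part matters and whether the rise holds beyond compound 4.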